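Replacing chloro with methyl in compound 1

The source may hold more compounds than are shown below. What is called first, only, known or untested is meant among the compounds shown, and "the series" means these compounds.

Among the compounds with values here, compound 1 (`O=C1c2ccccc2C(=O)N1CCOC(=S)N(C(=O)c1ccccc1[N+](=O)[O-])c1ccc(Cl)cc1`) gives 21000 nM in an ADME assay on MT4 cells (Homo sapiens) for cytotoxicity, read by MTT assay (on this read-out lower numbers stand for higher toxicity in this test and higher numbers for lower toxicity in this test), and it is the only exact number so far in this small set. Compound 2 (`O=C1c2ccccc2C(=O)N1CCOC(=S)N(C(=O)c1ccc([N+](=O)[O-])cc1)c1ccc(Cl)cc1`) gives > 100000 nM as its reading, and this is a limit of the assay, not a number. Within the data shown here, the only measured step (an at least 4.7-fold higher number from compound 1 to compound 2 (0.67 log units; beyond the scatter)) puts 4-nitrophenyl in place of 2-nitrophenyl on a carbonyl carbon and leaves the chloro group untouched.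

Compound 3 (`Cc1ccc(N(C(=O)c2ccccc2[N+](=O)[O-])C(=S)OCCN2C(=O)c3ccccc3C2=O)cc1`) keeps the 2-nitrophenyl of compound 1 but carries methyl in place of chloro on an aromatic carbon, para to a large group (methyl in place of chloro on an aromatic carbon). Among the measured compounds shown here, no measured step involves this change, so the size of the nitrophenyl step cannot be carried over to it. In this assay no step beyond the scatter is therefore expected, and the estimate stays anchored on compound 1 (21000 nM), with a wide margin on either side. The expected shift (a 1.2-fold higher number from compound 1 to compound 3 (0.08 log units; within the scatter)) is small. Compound 3 is expected at 25000 nM (estimated range 9000 nM to 80000 nM).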

Compound 3, half-maximal cytotoxic concentration: 100000 nM
For compound 3 the middle estimate is 4.0-fold (0.60 log units) below the measured one; the whole stated range lies below it.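

In this assay, methyl in place of chloro on an aromatic carbon gives a 4.8-fold higher number from compound 1 to compound 3 (0.68 log units; beyond the scatter), so this place on the core of compound 1, which stayed untouched in the earlier step, also bears on the read-out, and the nitrophenyl group is not the only part that does. On this read-out, compound 3 is less toxic in this test than compound 1, although the change brings no ring, no hydrogen-bond donor or acceptor and no net charge. How far the number might rise beyond compound 3 cannot be read, because its value stands at the edge of what this test reports: the limit of > 100000 nM in this assay, at which 1 of the 3 values shown sits.

The compounds shown leave open whether the step follows from the loss of chloro or from the arrival of methyl, and how a fluoro group, a methoxy group or an amine at the same place would read. On these data alone, compound 2 gives > 100000 nM, which is a limit of the assay and not a number, and what methyl in place of chloro would do in that compound, with its 4-nitrophenyl, also stays open.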